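The source may hold more compounds than are shown below. What is called first, only, known or untested is meant among the compounds shown, and "the series" means these compounds.

Measured compounds in a functional assay on HCC1806 cells (Homo sapiens) for inhibition, read by sulforhodamine B assay, tested at 10 uM; on this read-out lower numbers stand for less inhibition and higher numbers for more inhibition at the one concentration tested (going by the name of the read-out):

compound 1 `COC(=O)CC(=O)N1N=C(c2ccc(-n3cncn3)cc2)CC1c1ccc(N(C)C)cc1` — -7.8%
compound 2 `CN(C)c1ccc(C2CC(c3ccc(-n4cncn4)cc3)=NN2C(=O)c2ccc(F)cc2)cc1` — 15.6%
compound 3 `CN(C)c1ccc(C2CC(c3ccc(-n4cncn4)cc3)=NN2S(=O)(=O)c2ccc(F)cc2)cc1` — 24.1%

Compound 3 stands at the top of these three numbers, but compound 2 sits within the scatter of it, so the two cannot be ordered; only compound 1 is clearly apart. The measured steps all concern the group on the ring nitrogen: a number 23.4 percentage points higher from compound 1 to compound 2 (beyond the scatter), a number 31.9 percentage points higher from compound 1 to compound 3 (beyond the scatter) and a number 8.5 percentage points higher from compound 2 to compound 3 (within the scatter). Compound 4 `CN(C)c1ccc(C2CC(c3ccc(-n4cncn4)cc3)=NN2S(=O)(=O)c2ccc(OC(F)(F)F)cc2)cc1` keeps the (4-fluorophenyl)sulfonyl arrangement of compound 3 and changes only the aromatic substituent: trifluoromethoxy in place of fluoro on an aromatic carbon. The same difference, cut one bond further out, reads 4-fluorophenyl to 4-(trifluoromethoxy)phenyl. For the measured compounds named here, no measured step touches this position, so nothing here shows what such a change does. With compound 3 as the only anchor, the expected step is a number 0.9 percentage points higher from compound 3 to compound 4 (within the scatter), not beyond the scatter in either direction. Compound 4 is therefore estimated at 25%, within a range from 5% to 45%.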

Compound 4, a percentage reported as inhibition, at one concentration (the size of the read-out at that concentration, not a potency): 25.2%
Compound 4: middle estimate off by 0.2 percentage points, on the low side; measured number inside the range.
By their numbers in this assay, from the lowest: compound 1; then compounds 2, 3 and 4 (each within the scatter of the next).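

In this assay, for the compounds shown here, trifluoromethoxy in place of fluoro on an aromatic carbon para to a large group gives a number 1.1 percentage points higher from compound 3 to compound 4 (within the scatter), the first measured step at this position. Going from one heavy atom to five, and adding a hydrogen-bond acceptor, therefore leaves the read-out with no change that can be told from scatter, at least on the sulfonyl compounds. No measurement at hand bears on why this swap behaves as it does.

Fluoro and trifluoromethoxy are the only two groups seen here, so it remains open whether an amine, a carboxylic acid or a longer alkoxy chain at this position would move the number beyond the scatter. Also open, from the compounds shown here alone, is whether the same swap would give a similar step on the carbonyl-linked compound 2 .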